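Mirror image of a fluorophenyl pyrrolidine in a fucosidase assay

A few compounds are considered here, and "the series" means these few. Any claim that something is new, unique, unknown or untested is made for them only; others in the source may bear on it.

Compound 2 `OC[C@]1(c2cccc(F)c2)NC[C@H](O)[C@H]1O` gives 0% in an assay on isolated protein for inhibition of tissue alpha-L-fucosidase (Bos taurus), tested at 1000 uM (a lower number here means less inhibition, a higher number more inhibition at the concentration tested (going by the name of the read-out)), level with compound 1 `OC[C@@]1(c2ccc(F)cc2)NC[C@@H](O)[C@@H]1O` at 0% and together the lowest of three numbers; compound 3 `COc1ccc([C@]2(CO)NC[C@@H](O)[C@@H]2O)cc1` gives 2.7%. Among the compounds with values here, the only measured step, a number 2.7 percentage points higher from compound 1 to compound 3 (within the scatter), stays within the scatter. Compound 4 `OC[C@@]1(c2cccc(F)c2)NC[C@@H](O)[C@@H]1O` differs from compound 2 in this way: the two compounds have the same atoms and bonds and differ only in configuration as drawn: 3 of 3 stereo elements differ (all stereocentres are inverted: mirror images); a stereocentre at a saturated ring carbon is drawn S in compound 2 and R in compound 4; a stereocentre at a saturated ring carbon is drawn S in compound 2 and R in compound 4; a stereocentre at a saturated ring carbon is drawn S in compound 2 and R in compound 4. Within the data shown here, no measured step compares mirror images, so nothing directly bears on this change; compound 1 and compound 3, which share the configuration of compound 4, both sit near zero. Compound 4 is therefore expected to move by a number 1 percentage points higher from compound 2 to compound 4 (within the scatter), nothing beyond the scatter. The estimate for compound 4 is 1%, between 0% and 10%.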

Compound 4, a percentage reported as inhibition, at one concentration (the size of the read-out at that concentration, not a potency): 0%
The estimate for compound 4 lay 1 percentage points above the measured number; the range from low to high includes it.
By their numbers in this assay, from the lowest: compounds 1, 2, 4 and 3 (each within the scatter of the next).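

In this assay, within the data shown here, this mirror-image pair gives the first direct comparison of configuration, with no change at the digits printed from compound 2 to compound 4 (within the scatter). The comparison speaks to configuration alone because of one point: the fact that compounds 2 and 4 differ only in the configuration as drawn. Inverting all three stereocentres therefore brings no reading beyond the scatter, but with neither compound showing inhibition, this cannot show how configuration would matter in a compound that does inhibit.

The compounds shown leave open whether another group on the aromatic ring, such as an amine or a carboxylic acid, would give inhibition beyond the scatter in either configuration.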